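A nitrophenyl swap on the amide nitrogen

The source may hold more compounds than are shown below. What is called first, only, known or untested is meant among the compounds shown, and "the series" means these compounds.

In an ADME assay on MT4 cells (Homo sapiens) for cytotoxicity, read by MTT assay, with a stated time of 5 days (on this read-out lower numbers stand for higher toxicity in this test and higher numbers for lower toxicity in this test), compound 1 (`O=C(CSc1ncnn1-c1ccc(Cl)cc1Cl)Nc1ccccc1Cl`) gives 29100 nM, compound 2 (`O=C(CSc1ncnn1-c1ccc(Cl)cc1Cl)Nc1ccc(Cl)cc1Cl`) gives 172000 nM and compound 3 (`O=C(CSc1ncnn1-c1ccc(Cl)cc1Cl)Nc1cccnc1Cl`) gives 98500 nM. Compound 3 stays close to compound 2: a 1.7-fold lower number from compound 2 to compound 3 (0.24 log units; within the scatter). The gap to the remaining value is clearer: a 3.4-fold higher number from compound 1 to compound 3 (0.53 log units; beyond the scatter). Compound 4 (`O=C(CSc1ncnn1-c1ccc(Cl)cc1Cl)Nc1ccccc1[N+](=O)[O-]`) carries 2-nitrophenyl in place of 2-chloropyridin-3-yl on an amide-type nitrogen. For the measured compounds named here, no measured step makes this exact swap. The closest match to the entering group is the 2-chlorophenyl of compound 1, so a lower number is expected, with a step near the scatter and smaller than a 3.4-fold higher number from compound 1 to compound 3 (0.53 log units; beyond the scatter). The expected step is a 2.0-fold lower number from compound 3 to compound 4 (0.29 log units; within the scatter). For compound 4 the estimated value is 50000 nM, with an expected range from 18000 nM to 140000 nM.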

Compound 4, half-maximal cytotoxic concentration: 187000 nM
Compound 4: the middle estimate sits 3.7-fold (0.57 log units) below what was measured; measured number above the stated range.
By their numbers in this assay, from the lowest: compound 1; then compounds 3, 2 and 4 (each within the scatter of the next).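

In this assay, nitro in place of chloro on an aromatic carbon gives a clear rise, a 6.4-fold higher number from compound 1 to compound 4 (0.81 log units; beyond the scatter), which means less toxicity in this test. Compound 4 nevertheless sits with the other two compounds, with a 1.1-fold higher number from compound 2 to compound 4 (0.04 log units; within the scatter) and a 1.9-fold higher number from compound 3 to compound 4 (0.28 log units; within the scatter). For the compounds shown here, compound 1 is therefore the only clearly more toxic member of the four, and very different groups on the amide-type nitrogen give similar numbers.

No supporting data explain the rise seen with nitro. Going by these compounds, it also remains open whether an amine or a carboxylic acid in place of nitro would keep the number this high.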